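Anilinopropanoic acids: hydroxy for trifluoromethyl on the benzyl ring

The source may hold more compounds than are shown below. What is called first, only, known or untested is meant among the compounds shown, and "the series" means these compounds.

Measured so far:
- compound 1, `O=C(O)CCc1cccc(NCc2cccc(Oc3ccccc3)c2)c1`, 148%
- compound 2, `O=C(O)CCc1ccc(NCc2ccc(C(F)(F)F)cc2)cc1`, 133%
- compound 3, `O=C(O)CCc1ccc(NCc2cc(C(F)(F)F)cnc2Cl)cc1`, 112%

All three numbers come from a functional assay on CHO cells for agonist activity at Free fatty acid receptor 1 (Homo sapiens), read by reporter gene assay; a higher number here means a larger maximal response, a lower number a smaller maximal response. Compound 2 stands second highest of the three. Its nearest neighbour is compound 1, whose number lies higher by a margin beyond the scatter; the furthest is compound 3, whose number lies lower, again beyond the scatter. Among the compounds with values here, none of the three pairs differs in a single place, so no measured step exists that bears directly on the change considered next.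

Compound 4, `O=C(O)CCc1ccc(NCc2ccc(O)cc2)cc1`, is not yet measured. It differs from compound 2 by hydroxy in place of trifluoromethyl on an aromatic carbon.

Within the data shown here, with no measured step to lean on, the expectation rests on the spread of the three values alone. The step is expected to be small and, if anything, downward, with a fair chance that it stays within the scatter; the estimated step from compound 2 to compound 4 is a number 15 percentage points lower from compound 2 to compound 4 (beyond the scatter). In this assay compound 4 is therefore expected to give about 118%, the range running from 88% to 148%.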

Compound 4, largest response reached (reported as percent of maximum), in percent of the reference or control that the assay uses: 37%
Compound 4: the middle estimate sits 81 percentage points above what was measured; measured number below the stated range.
By their numbers in this assay, from the lowest: compound 4; then compound 3; then compound 2; then compound 1.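

In this assay, hydroxy in place of trifluoromethyl on an aromatic carbon, para to a large group, gives a number 96 percentage points lower from compound 2 to compound 4 (beyond the scatter). Within the data shown here, this is the first step that can be read at a single place, and it shows that the largest response reached depends strongly on the group at this carbon: the rest of the structure, shared by compound 2 and compound 4, does not keep the response of compound 2 on its own. No measurement shown here bears on what lies behind this drop.

On these data alone, with only one replacement at this carbon, it remains open whether the drop follows from the arrival of hydroxy or from the departure of trifluoromethyl; a methoxy group, a chlorine atom or a plain hydrogen at the same carbon would help to separate the two. Also open, as far as these compounds go, is whether the same change would have a step of similar size on the core of compound 1, where a phenoxy group takes the place of trifluoromethyl and the attachment on the acid-bearing ring differs.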